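A few compounds are considered here, and "the series" means these few. Any claim that something is new, unique, unknown or untested is made for them only; others in the source may bear on it.

Measured compounds:
- compound 1 `Cc1cccc(Cn2c(CN3CCN(C(=O)c4ccc(Cl)cc4)CC3)nc3ccccc32)c1` — 23.2%
- compound 2 `COc1cccc(Cn2c(CN3CCN(C(=O)C4CC4)CC3)nc3ccccc32)c1` — 44.4%
- compound 3 `O=C(C1CC1)N1CCN(Cc2nc3ccccc3n2Cc2ccc(C(F)(F)F)cc2)CC1` — 37%

In an assay on isolated protein for inhibition of aldehyde dehydrogenase 1A1 (Homo sapiens), read by spectrophotometry, tested at 10 uM (on this read-out lower numbers stand for less inhibition and higher numbers for more inhibition at the one concentration tested (going by the name of the read-out)), compound 1 stands lowest of the three numbers; compound 3 lies beyond the scatter above it, and compound 2 further still. For the measured compounds named here, the one single-place step, a number 7.4 percentage points lower from compound 2 to compound 3 (within the scatter), alters the group on the saturated chain carbon bound to an aromatic nitrogen and leaves the carbonyl untouched.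

Compound 4 `CC(=O)N1CCN(Cc2nc3ccccc3n2Cc2cccc(C)c2)CC1` differs from compound 1 by methyl in place of 4-chlorophenyl on a carbonyl carbon. Going by the values given here, no measured step bears on this change. Among the compounds with values here, compounds 2 and 3 carry a different group on the carbonyl carbon and gave higher numbers than compound 1, but each also differs from it at the chain carbon, so no step is given for them. The expected step of a number 9.8 percentage points higher from compound 1 to compound 4 (within the scatter) is therefore uncertain, with a modest rise considered possible. Compound 4 is estimated at 33%, in the range 12% to 54%.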

Compound 4, a percentage reported as inhibition, at one concentration (the size of the read-out at that concentration, not a potency): 70.3%
Compound 4: the middle estimate sits 37.3 percentage points below what was measured; measured number above the stated range.
By their numbers in this assay, from the lowest: compound 1; then compounds 3 and 2 (each within the scatter of the next); then compound 4.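

In this assay, the step at the carbonyl carbon is a number 47.1 percentage points higher from compound 1 to compound 4 (beyond the scatter), with methyl in place of 4-chlorophenyl and the rest of the structure unchanged. This first single-place reading at this position shows that the 4-chlorophenyl group is not required for inhibition at the concentration tested, and that this position can move the number beyond the scatter. No measured evidence accounts for the size of the step.

On these data alone, whether an ethyl or unsubstituted phenyl group on the carbonyl carbon would track with methyl or 4-chlorophenyl remains open. Cyclopropyl cannot be placed against methyl, as compounds 2 and 3 also differ from compound 4 at the chain carbon.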